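Chloro for Methoxy on the Pendant Phenyl of Compound 1

A few compounds are considered here, and "the series" means these few. Any claim that something is new, unique, unknown or untested is made for them only; others in the source may bear on it.

Measured compounds in a functional assay on BJAB cells (Homo sapiens) for antiproliferative activity, with a stated time of 4 days; on this read-out higher numbers stand for an effect only at larger amounts of compound and lower numbers for an effect already at smaller amounts:
- compound 1, `COc1ccc(-c2c(C)nn(-c3nc(-c4ccc(Cl)c(Cl)c4)c(SC(C)C)s3)c2C(=O)O)cc1`, 2100 nM
- compound 2, `Cc1cc(Cl)cc(-c2c(C)nn(-c3nc(-c4ccc(Cl)c(Cl)c4)c(SC(C)C)s3)c2C(=O)O)c1`, 663 nM
- compound 3, `Cc1nn(-c2nc(-c3ccc(Cl)c(Cl)c3)c(SC(C)C)s2)c(C(=O)O)c1-c1cncc(C#N)c1`, 20000 nM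

Among these three, compound 1 holds the second highest number: compound 2 sits closest to it, while compound 3 lies furthest away on the high side. The compound not yet measured is compound 4, `Cc1nn(-c2nc(-c3ccc(Cl)c(Cl)c3)c(SC(C)C)s2)c(C(=O)O)c1-c1cccc(Cl)c1`. Its change from compound 1 is 3-chlorophenyl in place of 4-methoxyphenyl on an aromatic carbon.

Among the measured compounds shown here, two measured steps bear on this change. The first is a 3.2-fold lower number from compound 1 to compound 2 (0.50 log units; beyond the scatter), where the same position on the shared core of compound 1 takes a phenyl carrying both a chlorine and a methyl group, and the number falls. The second is a 9.5-fold higher number from compound 1 to compound 3 (0.98 log units; beyond the scatter), where a nitrogen-containing ring carrying a nitrile enters instead, and the number rises strongly. Compound 4 carries a chlorophenyl like compound 2 but without the methyl group, so a step in the same direction as that to compound 2, though likely smaller, is expected. The estimated step is a 2.3-fold lower number from compound 1 to compound 4 (0.37 log units; beyond the scatter). Compound 4 is therefore expected to give about 900 nM in this assay, with a range from 350 nM to 2500 nM.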

Compound 4, half-maximal effective concentration: 13600 nM
Compound 4: middle estimate off by 15-fold (1.18 log units), on the low side; the measured number lies above the stated range.
By their numbers in this assay, from the lowest: compound 2; then compound 1; then compounds 4 and 3 (each within the scatter of the next).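

In this assay, the chlorine of the 3-chlorophenyl group does not by itself carry the change seen in compound 2, since hydrogen in place of methyl on an aromatic carbon of that ring gives a 21-fold higher number from compound 2 to compound 4 (1.31 log units; beyond the scatter) and so separates two close relatives by a wide margin. Replacing the 4-methoxyphenyl group with 3-chlorophenyl gives a 6.5-fold higher number from compound 1 to compound 4 (0.81 log units; beyond the scatter) in the same direction as the step to the 5-cyanopyridin-3-yl compound, so among the four compounds only compound 2 has a lower number than compound 1. The 3-chlorophenyl and 5-cyanopyridin-3-yl groups cannot be told apart here, with a 1.5-fold lower number from compound 3 to compound 4 (0.17 log units; within the scatter) as the step between them, which shows that two quite different rings at this position can end up at the same level.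

Nothing shown here explains why a single methyl group matters so much at this position. From the compounds shown here alone, it also remains open whether that methyl group is specifically required, which a 3-chlorophenyl ring bearing an ethyl group or an amine in its place, or a 3-methylphenyl ring without the chlorine, would address.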